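Chloro to trifluoromethyl beside the urea arm: compound 3

The source may report more compounds than this note shows. Statements on the series, on what has been measured and on what is new or still open speak of the compounds shown alone.

Two compounds of the series have numbers in a functional assay for antagonist activity at transient receptor potential cation channel subfamily V member 1 (Homo sapiens), read by calcium flux; a higher number here means a weaker inhibitor, a lower number a stronger inhibitor. Compound 1 `O=C(NCc1ccc(N2CCCCCC2)cc1C(F)(F)F)Nc1cccc2cnccc12` gives 5.7 nM in this assay. For the measured compounds named here, compound 2 `O=C(NCc1ccc(N2CCCCCC2)cc1Cl)Nc1cccc2[nH]ncc12` gives 190 nM in this assay, the higher of the two numbers; the gap to compound 1 lies beyond the scatter, but compound 1 differs from compound 2 in two places at once, so no single step is defined between them, and the two values show only that compound 1 sits well below compound 2.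

Compound 3 `O=C(NCc1ccc(N2CCCCCC2)cc1C(F)(F)F)Nc1cccc2[nH]ncc12` has not been measured. It differs from compound 2 by trifluoromethyl in place of chloro on an aromatic carbon; the rest of the molecule stays as in compound 2. Compound 1 carries the same trifluoromethyl group and gives 5.7 nM in this assay, but its other difference from compound 2 means it cannot fix the size of this step on its own. A modest downward step is expected, a 2.7-fold lower number from compound 2 to compound 3 (0.43 log units; beyond the scatter), with no certainty that it clears the scatter. Compound 3 is therefore estimated at 70 nM in this assay, within a range of 20 nM to 300 nM.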

Compound 3, half-maximal inhibitory concentration: 133 nM
Compound 3: the middle estimate sits 1.9-fold (0.28 log units) below what was measured; the range from low to high includes it.
By their numbers in this assay, from the lowest: compound 1; then compounds 3 and 2 (each within the scatter of the next).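

In this assay, trifluoromethyl in place of chloro on the aromatic carbon ortho to a large group gives a 1.4-fold lower number from compound 2 to compound 3 (0.15 log units; within the scatter), so with 1H-indazol-4-yl on the amide-type nitrogen these two substituents cannot be told apart at this position. For the compounds shown here, with trifluoromethyl held constant, 1H-indazol-4-yl in place of isoquinolin-5-yl on that nitrogen gives a 23-fold higher number from compound 1 to compound 3 (1.37 log units; beyond the scatter), so among the single changes now readable, only this one produces a step beyond the scatter. No measurement at hand accounts for either step.

Still open, going by these compounds, is whether chloro and trifluoromethyl also read alike with isoquinolin-5-yl on the amide-type nitrogen, as the two substituents are compared here only with 1H-indazol-4-yl. Also open, on these data alone, is how a nitrile or a methoxy group on the same aromatic carbon, or a dimethylamino group in place of the azepan-1-yl group, would read in this assay.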